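A few compounds are considered here, and "the series" means these few. Any claim that something is new, unique, unknown or untested is made for them only; others in the source may bear on it.

Compound 3 `CC(C(=O)NCc1ccc(C(F)(F)F)nc1-c1cccc(Cl)c1)c1ccc(NS(C)(=O)=O)c(F)c1` shows the lowest number of the three measured compounds in an assay on CHO cells for antagonist activity at transient receptor potential cation channel subfamily V member 1 (Homo sapiens), read by FLIPR (on this read-out higher numbers stand for weaker inhibition and lower numbers for stronger inhibition), giving 0.5 nM. Compound 2 `CC(C(=O)NCc1ccc(C(F)(F)F)nc1-c1ccc(Cl)cc1)c1ccc(NS(C)(=O)=O)c(F)c1` gives 0.7 nM, and the difference a 1.4-fold lower number from compound 2 to compound 3 (0.15 log units; within the scatter) is within the scatter, while compound 1 `CC(C(=O)NCc1ccc(C(F)(F)F)nc1-c1ccccc1)c1ccc(NS(C)(=O)=O)c(F)c1` gives 6.4 nM. The step to compound 4 `CC(C(=O)NCc1ccc(C(F)(F)F)nc1-c1ccc(N(C)C)cc1)c1ccc(NS(C)(=O)=O)c(F)c1` is 4-(dimethylamino)phenyl in place of 3-chlorophenyl on an aromatic carbon. Among the compounds with values here, the steps of a 9.1-fold lower number from compound 1 to compound 2 (0.96 log units; beyond the scatter) and a 13-fold lower number from compound 1 to compound 3 (1.11 log units; beyond the scatter) show what a chloro group adds, but no measured compound carries a dimethylamino group on this phenyl ring, so its effect is unknown. The step is therefore expected to run toward a higher number, a 6.0-fold higher number from compound 3 to compound 4 (0.78 log units; beyond the scatter), landing between compound 1 and compound 3. Compound 4 is estimated at 3 nM, with a likely range from 0.7 nM to 15 nM.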

Compound 4, inhibition constant: 3.2 nM
Estimate against measurement, compound 4: 1.1-fold (0.03 log units) below; the range from low to high includes it.
By their numbers in this assay, from the lowest: compounds 3 and 2 (each within the scatter of the next); then compounds 4 and 1 (each within the scatter of the next).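

In this assay the dimethylamino group on this phenyl ring does not match chloro: a 4.6-fold higher number from compound 2 to compound 4 (0.66 log units; beyond the scatter) and a 6.4-fold higher number from compound 3 to compound 4 (0.81 log units; beyond the scatter) both lie beyond the scatter. Against the bare phenyl ring, a 2.0-fold lower number from compound 1 to compound 4 (0.30 log units; within the scatter) lies within the scatter, so here dimethylamino cannot be told apart from hydrogen. No measurement at hand bears on why the two groups differ. The compounds shown leave open whether 4-methoxyphenyl or 4-fluorophenyl in the same place would follow chloro or dimethylamino.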